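Methyl for Hydrogen at Two Different Chain Carbons

The source may report more compounds than this note shows. Statements on the series, on what has been measured and on what is new or still open speak of the compounds shown alone.

The compounds measured so far in a functional assay for antagonist activity at Neuropeptide Y receptor type 2 (Homo sapiens); on this read-out lower numbers stand for stronger inhibition and higher numbers for weaker inhibition:
compound 1, `CCOc1ccc(NC(=S)N2CCC(C(O)(c3ccccc3)c3ccccc3)CC2)cc1C#N`, gives 323 nM
compound 2, `CC(C)Oc1ccc(NC(=S)N2CCC(C(O)(c3ccccc3)c3ccccc3)CC2)cc1C#N`, gives 899 nM
compound 3, `CS(=O)(=O)c1ccc(OC(=O)N2CCC(C(O)(c3ccccc3)c3ccccc3)CC2)cc1`, gives 141 nM

Compound 1 and compound 2 share one core, while compound 3 is built on another; the difference between the two cores is not broken down here. Of the three numbers, compound 3 holds the lowest, and its gaps to compound 1 and to compound 2 both lie beyond the scatter.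

Within the data shown here, the only counted step among the measured compounds runs from compound 1 to compound 2. The change there is methyl in place of hydrogen on a saturated chain carbon bound to an oxygen on an aromatic ring and a saturated chain carbon and it produced a 2.8-fold higher number from compound 1 to compound 2 (0.44 log units; beyond the scatter).

Compound 4, `CCS(=O)(=O)c1ccc(OC(=O)N2CCC(C(O)(c3ccccc3)c3ccccc3)CC2)cc1`, has not yet been measured in this assay. It differs from compound 3 by methyl in place of hydrogen on a saturated chain carbon bound to a sulfonyl sulfur. Among the measured compounds shown here, this is the same kind of change as the one from compound 1 to compound 2, not the same change: in the earlier pair the carbon that takes the methyl is bound to an oxygen on an aromatic ring and a saturated chain carbon, whereas in compound 4 it is bound to a sulfonyl sulfur.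

With a single earlier example, and that one on a different core and at a different place, the expectation for compound 4 rests lightly on it. For the measured compounds named here, the step from compound 3 to compound 4 is expected to be a 1.8-fold higher number from compound 3 to compound 4 (0.25 log units; within the scatter), a weakening in the same direction but smaller than the earlier one, because a 2.8-fold higher number from compound 1 to compound 2 (0.44 log units; beyond the scatter) is the only guide available. Compound 4 is therefore estimated at 250 nM in this assay, most likely between 100 nM and 700 nM.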

Compound 4, half-maximal inhibitory concentration: 59 nM
For compound 4 the middle estimate is 4.2-fold (0.63 log units) above the measured one; measured number outside the range, below it.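

In this assay, methyl in place of hydrogen on a saturated chain carbon bound to a sulfonyl sulfur, the change from methylsulfonyl to ethylsulfonyl, gave a 2.4-fold lower number from compound 3 to compound 4 (0.38 log units; beyond the scatter), whereas the earlier methyl step on the other core had raised the number. Methyl for hydrogen on a saturated chain carbon therefore has no single direction of effect across these two pairs, and the gap between the two steps is larger than scatter alone would account for: the same change on two cores in this assay, a 2.8-fold higher number (0.44 log units; beyond the scatter) from compound 1 to compound 2 and a 2.4-fold lower number (0.38 log units; beyond the scatter) from compound 3 to compound 4, 6.7-fold (0.82 log units) apart, beyond the scatter of two such steps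

This does not show whether the core or the carbon that takes the methyl governs the outcome, as the two pairs differ in both and the data do not separate them; a single pair on each core also gives no general rule for either core.

The compounds shown leave open whether the number would keep falling with a longer chain on the sulfonyl group, such as propyl, or with a branched one, such as isopropyl. They also leave open how an amine in place of the sulfonyl chain would read, and whether the methyl step would go the same way on the core of compound 1 if it were placed elsewhere.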